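Methyl on a Ring Nitrogen: From No Number to One?

A few compounds are considered here, and "the series" means these few. Any claim that something is new, unique, unknown or untested is made for them only; others in the source may bear on it.

Compound 1 `COc1ccccc1/C=c1/[nH]c(=O)/c(=C\c2cccc(Cl)c2Cl)[nH]c1=O`: "not active" (no number reported)
Compound 2 `C=CCn1c(=O)/c(=C\c2ccccc2OC)[nH]c(=O)/c1=C\c1ccccc1OC`: 5100 nM
Compound 3 `C=CCn1c(=O)/c(=C\c2cccc(Br)c2)[nH]c(=O)/c1=C\c1ccccc1OC`: 1100 nM

In a functional assay on U-937 cells (Homo sapiens) for cytotoxicity, read by CCK-8 assay, with a stated time of 72 h (on this read-out higher numbers stand for weaker inhibition and lower numbers for stronger inhibition), compound 1 gives "not active" (no number reported), so no single number places it. Compound 2 and compound 3 both give measurable numbers in this assay, and both carry a group on an aromatic nitrogen of the shared core, where compound 1 carries hydrogen. Compound 4 `COc1ccccc1/C=c1\c(=O)[nH]/c(=C/c2cccc(Cl)c2Cl)c(=O)n1C` differs from compound 1 by methyl in place of hydrogen on an aromatic nitrogen. Within the data shown here, the only measured step, a 4.6-fold lower number from compound 2 to compound 3 (0.67 log units; beyond the scatter), concerns a different part of the shared core and so says nothing about what a methyl on the ring nitrogen does. Compound 4 is therefore expected to show weak inhibition at best in this assay, with a real chance of no number at all. For compound 4 the estimated value is 8000 nM, with a range from 2000 nM to 40000 nM.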

Compound 4, half-maximal inhibitory concentration: 100 nM
For compound 4 the middle estimate is 80-fold (1.90 log units) above the measured one; measured number outside the range, below it.
By their numbers in this assay, from the lowest: compound 4; then compound 3; then compound 2.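

Among these compounds, compound 1 has no number, so no step from it to compound 4 can be read. How far the methyl on the aromatic nitrogen shifts the number stays open, and no measurement shown explains the result.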